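Methoxy on compound 1: expected cytotoxicity of compound 4

The source may hold more compounds than are shown below. What is called first, only, known or untested is meant among the compounds shown, and "the series" means these compounds.

Measured so far in an ADME assay on L6 cells (Rattus norvegicus) for cytotoxicity (a lower number here means a stronger inhibitor, a higher number a weaker inhibitor), as follows:
- compound 1 `c1cc(-c2cc3ccc(C4=NCCN4)cc3o2)ccc1C1=NCCN1` gives 4500 nM
- compound 2 `COc1cc(C(=N)NC(C)C)cc2cc(-c3ccc(C(=N)NC(C)C)cc3)oc12` gives > 190000 nM (a limit)
- compound 3 `N=C(N)c1ccc(-c2cc3cc(C(=N)N)cc(O)c3o2)c(O)c1` gives 2100 nM

Of the two actual numbers, compound 1 holds the higher, and compound 3 lies lower by more than the scatter. The entry for compound 2 is a limit of the assay and not a number.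

Still unmeasured is compound 4 `COc1cc(C2=NCCN2)ccc1-c1cc2ccc(C3=NCCN3)cc2o1`, which differs from compound 1 by methoxy in place of hydrogen on an aromatic carbon, ortho to a large group and meta to a group of 5 heavy atoms (methoxy in place of hydrogen on an aromatic carbon).

For the measured compounds named here, no measured pair isolates this change. Compound 2 at > 190000 nM, again a limit, also bears a methoxy but differs from compound 1 elsewhere too, which makes it a weak guide. The step of a 1.3-fold higher number from compound 1 to compound 4 (0.12 log units; within the scatter) is expected to be small, towards a higher number, and may stay within the scatter. For compound 4 the estimated value is 6000 nM, with an expected range from 1800 nM to 25000 nM in this assay.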

Compound 4, half-maximal inhibitory concentration: 4400 nM
Estimate against measurement, compound 4: 1.4-fold (0.13 log units) above; the measured number falls inside the stated range.
By their numbers in this assay, from the lowest: compound 3; then compounds 4 and 1 (each within the scatter of the next). At a limit, above all of these: compound 2.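

In this assay, methoxy in place of hydrogen on an aromatic carbon, ortho to a large group and meta to a group of 5 heavy atoms, gives a 1.0-fold lower number from compound 1 to compound 4 (0.01 log units; within the scatter). For the compounds shown here, this is the first pair that isolates a single change, and at this position on the core of compound 1 the methoxy leaves the read-out within the scatter. Methoxy alone on this core therefore does not reproduce what is seen for compound 2, whose entry is a limit of the assay and not a number: the limit of > 190000 nM in this assay, at which 1 of the 4 values shown sits.

Open, from the compounds shown here alone, is whether an ethoxy group or a primary amine at this position would leave the read-out equally unmoved. Also open, going by these compounds, is whether methoxy elsewhere on the shared core, or on a compound with the end groups of compound 2 or compound 3, would behave the same way.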